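Fluorophenyl positional swap on the isoxazole aryl group

The compounds below may be only part of what the source reports. "The series", "measured", "known", "first", "only" and "open" are said of these compounds alone.

Measured so far, in a functional assay on Huh-7 cells (Homo sapiens) for cytotoxicity, with a stated time of 48 h; on this read-out higher numbers stand for weaker inhibition and lower numbers for stronger inhibition:
compound 1 `N#Cc1ccc(-c2cc(COC(Cc3cn(C4CCN(Cc5ccc([N+](=O)[O-])cc5)CC4)nn3)c3ccc(Br)cc3)on2)cc1` gives 5000 nM
compound 2 `O=[N+]([O-])c1ccc(CN2CCC(n3cc(CC(OCc4cc(-c5cccc(F)c5)no4)c4ccc(Br)cc4)nn3)CC2)cc1` gives 3000 nM

The change from compound 1 to compound 2, 3-fluorophenyl in place of 4-cyanophenyl on an aromatic carbon, gave a 1.7-fold lower number from compound 1 to compound 2 (0.22 log units; within the scatter), so compound 2 and compound 1 sit within the scatter of each other and no ranking follows.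

Compound 3 `O=[N+]([O-])c1ccc(CN2CCC(n3cc(CC(OCc4cc(-c5ccccc5F)no4)c4ccc(Br)cc4)nn3)CC2)cc1` differs from compound 2 by 2-fluorophenyl in place of 3-fluorophenyl on an aromatic carbon. Within the data shown here, the only step that bears on this position, from compound 1 to compound 2, stayed within the scatter, so no step beyond the scatter is expected in this assay; the expected step is no change at the digits printed from compound 2 to compound 3 (within the scatter). Compound 3 is estimated at 3000 nM, with a range of 1200 nM to 8000 nM.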

Compound 3, half-maximal inhibitory concentration: 2000 nM
For compound 3 the middle estimate is 1.5-fold (0.18 log units) above the measured one; the range from low to high includes it.
By their numbers in this assay, from the lowest: compounds 3, 2 and 1 (each within the scatter of the next, the first and the last beyond it).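

In this assay 2-fluorophenyl in place of 3-fluorophenyl gives a 1.5-fold lower number from compound 2 to compound 3 (0.18 log units; within the scatter) and leaves these two fluorophenyl isomers unranked. Against 4-cyanophenyl, 2-fluorophenyl gives a 2.5-fold lower number from compound 1 to compound 3 (0.40 log units; beyond the scatter) as the first step at this position beyond the scatter, though a modest one. Nothing available bears on the reason for this step.

Still open, on these data alone, is whether 4-fluorophenyl, unsubstituted phenyl or a phenyl carrying an amine or a carboxylic acid would separate from compound 3 at this position.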